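Methoxy for Methyl on Compound 3

A few compounds are considered here, and "the series" means these few. Any claim that something is new, unique, unknown or untested is made for them only; others in the source may bear on it.

In an ADME assay on HEK-293T cells (Homo sapiens) for inhibition, read by CCK-8 assay, with a stated time of 48 h, tested at 20 uM (on this read-out higher numbers stand for more inhibition of growth at the one concentration tested and lower numbers for less inhibition of growth), compound 1 `Cc1ccc(S(=O)(=O)Oc2ccccc2/C=C(\C#N)C(=O)Nc2nnc(C)s2)cc1` gives 35% and compound 2 `COc1ccc(S(=O)(=O)Oc2ccccc2/C=C(\C#N)C(=O)Nc2nnc(-c3cccs3)s2)cc1` gives 40% while compound 3 `COc1ccc(Cc2nnc(NC(=O)/C(C#N)=C/c3ccccc3OS(=O)(=O)c3ccc(C)cc3)s2)cc1` gives 21% as the lowest of the three. Compound 4 `COc1ccc(Cc2nnc(NC(=O)/C(C#N)=C/c3ccccc3OS(=O)(=O)c3ccc(OC)cc3)s2)cc1` has no number yet. It differs from compound 3 by methoxy in place of methyl on an aromatic carbon, and methoxy in place of methyl on an aromatic carbon counts what that swap changes. Among the compounds with values here, the one measured single change is a number 14 percentage points lower from compound 1 to compound 3 (beyond the scatter) and this modest step concerns a different group, so it offers only weak guidance. Compound 2 at 40% also carries (4-methoxyphenyl)sulfonyl and stands higher than compound 3, but it differs in another group as well. Within the data shown here, no measured step isolates the swap, so only a small upward drift is expected, and no step beyond the scatter. The estimate is a number 4 percentage points higher from compound 3 to compound 4 (within the scatter) in this assay for now. For compound 4 the expected value is 25% within an estimated range from 12% to 38% on this read-out.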

Compound 4, percent growth inhibition at one concentration: 30%
Beside the measured number, compound 4's estimate is 5 percentage points below it; measured number inside the range.
By their numbers in this assay, from the lowest: compounds 3, 4, 1 and 2 (each within the scatter of the next, the first and the last beyond it).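

Within the data shown here, replacing 4-methylphenyl with 4-methoxyphenyl gives the first direct reading of this aromatic carbon in this assay, and the result is a number 9 percentage points higher from compound 3 to compound 4 (within the scatter), so methyl and methoxy cannot be told apart here while 4-methoxybenzyl stays in place. With (4-methoxyphenyl)sulfonyl kept the same, the exchange of thiophen-2-yl for 4-methoxybenzyl gives a number 10 percentage points lower from compound 2 to compound 4 (within the scatter), so this pair cannot be separated either. No measurement shown here offers an explanation for either step.

Still open, on these data alone, is whether a different group on this aromatic carbon, such as an ethoxy group, a chlorine atom or an amine, would shift the growth inhibition beyond the usual scatter. As far as these compounds go, it is also open whether methoxy in place of methyl would read the same with the smaller methyl group or with thiophen-2-yl in place of 4-methoxybenzyl.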